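This account rests on a few compounds, and the source may have more. Where it says the series, first, only, none or still open, it means among the compounds named here.

Working notes on the series. Compound 1 `CCCCCCC(=O)Oc1ccccc1-c1cc2ccccc2[nH]1` is assessed in a functional assay on U-251 cells (Homo sapiens) for antiproliferative activity, read by sulforhodamine B assay, with a stated time of 72 h (a lower number here means that less compound is needed, a higher number that more compound is needed for the effect), alongside compound 2 `Oc1ccccc1-c1ccc2ccccc2c1` and compound 3 `Oc1ccccc1-c1c[nH]c2ccccc12`. Compound 1 gives 38000 nM, the lowest of the three numbers; compound 2 gives 92000 nM and compound 3 gives 95000 nM, both beyond the scatter above compound 1. Compound 4 `Oc1ccccc1-c1cc2ccccc2[nH]1` is not yet measured and differs from compound 1 by hydrogen in place of hexylcarbonyl on an oxygen on an aromatic ring. For the measured compounds named here, no measured pair shows this exact change, so its size is uncertain. Compound 2 at 92000 nM and compound 3 at 95000 nM, each carrying a free hydroxyl on the aromatic ring, point to a moderate rise for compound 4, though their cores differ from the core of compound 1. The expected step of a 1.7-fold higher number from compound 1 to compound 4 (0.23 log units; within the scatter) is modest and upward. Compound 4 is estimated at 65000 nM, within 25000 nM to 160000 nM.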

Compound 4, half-maximal effective concentration: 130000 nM
Compound 4: middle estimate off by 2.0-fold (0.30 log units), on the low side, and the stated range covers the measured number.
By their numbers in this assay, from the lowest: compound 1; then compounds 2, 3 and 4 (each within the scatter of the next).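

In this assay, for the compounds shown here, hydrogen in place of hexylcarbonyl on an oxygen on an aromatic ring gives a 3.4-fold higher number from compound 1 to compound 4 (0.53 log units; beyond the scatter) on an otherwise unchanged structure, the first direct reading of this change. At this position, hexylcarbonyl goes with the lower number, though this single pair sets no pattern. No measurement bears on the reason for the step. As far as these compounds go, it remains open whether a shorter acyl chain, a longer acyl chain or a methyl ether on this oxygen would give a similar number. Also open, from the compounds shown here alone, is whether hexylcarbonyl would give a similar step on the cores of compound 2 and compound 3.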